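Adding a Third Methoxy to the Ketone-Side Ring

This account rests on a few compounds, and the source may have more. Where it says the series, first, only, none or still open, it means among the compounds named here.

Measured compounds:
- Compound 1, `COc1cc(-c2cc(/C=C/C(=O)c3ccc(Cl)c(Cl)c3)[nH]n2)cc(OC)c1OC`: 68000 nM
- Compound 2, `COc1ccc(C(=O)/C=C/c2cc(-c3cc(OC)c(OC)c(OC)c3)n[nH]2)cc1OC`: 2860 nM

Both were tested in a functional assay on 786-0 cells (Homo sapiens) for inhibition, read by sulforhodamine B assay, with a stated time of 48 h; on this read-out lower numbers stand for stronger inhibition of growth and higher numbers for weaker inhibition of growth. Compound 2 has the lowest of the two numbers; the nearest is compound 1, whose number is higher by a 24-fold lower number from compound 1 to compound 2 (1.38 log units; beyond the scatter), a large step produced by a single swap of groups on the ring attached to the carbonyl. Compound 3, `COc1cc(C(=O)/C=C/c2cc(-c3cc(OC)c(OC)c(OC)c3)n[nH]2)cc(OC)c1OC`, differs from compound 2 in one place: methoxy in place of hydrogen on an aromatic carbon. No measured step covers this exact change, so the only guidance is that the ring on the carbonyl has already shown large sensitivity in the step from compound 1 to compound 2. With a small addition to an already favourable pattern, the expected step is a 1.4-fold lower number from compound 2 to compound 3 (0.16 log units; within the scatter), likely within the scatter or a modest improvement. Compound 3 is therefore estimated at 2000 nM, with a range from 500 nM to 8000 nM.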

Compound 3, concentration for total growth inhibition: 3250 nM
Beside the measured number, compound 3's estimate is 1.6-fold (0.21 log units) below it; low and high end bracket the measured number.
By their numbers in this assay, from the lowest: compounds 2 and 3 (each within the scatter of the next); then compound 1.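

In this assay, adding the methoxy group to the ring on the carbonyl gives a 1.1-fold higher number from compound 2 to compound 3 (0.06 log units; within the scatter) and so leaves compound 2 and compound 3 indistinguishable. The earlier swap on this same ring gave a 24-fold lower number from compound 1 to compound 2 (1.38 log units; beyond the scatter) and showed that the ring can matter a great deal, while the new step shows that this does not hold for every change on it: this aromatic carbon, ortho to a methoxy group, takes the added methoxy with no difference beyond the scatter. Nothing available explains why the added methoxy makes so little difference.

On these data alone, what stays open is whether this carbon would accept a different group as readily, such as an amine, a hydroxyl or a longer chain like ethoxy. These compounds also cannot show whether a methoxy group here matters when the rest of the ring changes.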